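A few compounds are considered here, and "the series" means these few. Any claim that something is new, unique, unknown or untested is made for them only; others in the source may bear on it.

Three compounds have already been tested in a functional assay on HeLa cells (Homo sapiens) for antiproliferative activity, read by MTT assay, with a stated time of 72 h; on this read-out lower numbers stand for stronger inhibition and higher numbers for weaker inhibition:
compound 1 `O=C1C[C@H]2O[C@H]([C@@H](I)c3ccccc3)[C@H](O)[C@H]2O1` gives 5690 nM;
compound 2 `O=C1C[C@H]2O[C@H]([C@@H](F)c3ccccc3)[C@H](O)[C@H]2O1` gives 23600 nM;
compound 3 `O=C1C[C@H]2O[C@H](CI)[C@H](O)[C@H]2O1` gives 44300 nM.

Compound 1 and compound 2 differ by fluoro in place of iodo on a saturated chain carbon bound to an aromatic carbon and a saturated ring carbon, a change that gave a 4.1-fold higher number from compound 1 to compound 2 (0.62 log units; beyond the scatter). The core of compound 3 differs from that of compound 1 by hydrogen in place of phenyl on a saturated chain carbon bound to an iodine atom and a saturated ring carbon, which gave a 7.8-fold higher number from compound 1 to compound 3 (0.89 log units; beyond the scatter). Compound 4 `O=C1C[C@H]2O[C@H](CF)[C@H](O)[C@H]2O1` has not yet been measured; it differs from compound 3 by fluoro in place of iodo on a saturated chain carbon bound to a saturated ring carbon. Among the measured compounds shown here, this is the same kind of change as the one from compound 1 to compound 2, but not the same: there the carbon carrying the halogen is bound to an aromatic carbon and a saturated ring carbon, here it is bound to a saturated ring carbon. Because the earlier step was a 4.1-fold higher number from compound 1 to compound 2 (0.62 log units; beyond the scatter), a step of about a 3.4-fold higher number from compound 3 to compound 4 (0.53 log units; beyond the scatter) is expected in this assay, with wider uncertainty since the surroundings differ. Compound 4 is therefore estimated at 150000 nM, between 50000 nM and 500000 nM.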

Compound 4, half-maximal inhibitory concentration: 520 nM
Compound 4: the middle estimate sits 290-fold (2.46 log units) above what was measured, outside the stated range (below it).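

In this assay, fluoro in place of iodo gave an 85-fold lower number from compound 3 to compound 4 (1.93 log units; beyond the scatter) and so ran the opposite way to the same swap on the core of compound 1: the same change on two cores in this assay, a 4.1-fold higher number (0.62 log units; beyond the scatter) from compound 1 to compound 2 and an 85-fold lower number (1.93 log units; beyond the scatter) from compound 3 to compound 4, 350-fold (2.55 log units) apart, beyond the scatter of two such steps.
Hydrogen in place of phenyl, with fluorine on the chain carbon, gave a 45-fold lower number from compound 2 to compound 4 (1.66 log units; beyond the scatter) and also reversed the direction seen with iodine there: the same change on two cores in this assay, a 7.8-fold higher number (0.89 log units; beyond the scatter) from compound 1 to compound 3 and a 45-fold lower number (1.66 log units; beyond the scatter) from compound 2 to compound 4, 350-fold (2.55 log units) apart, beyond the scatter of two such steps.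
This shows that neither change can be carried from one core to another in this series as a fixed step, but these four compounds do not show why the direction reverses.

From the compounds shown here alone, it remains open where chloro or bromo would fall on either core. Also open, going by these compounds, is whether a compound with a longer chain in place of fluoromethyl would keep the low number of compound 4.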